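Amino Substitution on Two Diyne Cores: Acid Dissociation

The source may report more compounds than this note shows. Statements on the series, on what has been measured and on what is new or still open speak of the compounds shown alone.

The series rests on two cores joined by the same diyne linker. Compound 1 `C(C#Cc1ccncc1)#Cc1ccccc1` and compound 2 `Nc1cc(C#CC#Cc2ccccc2)ccn1` share a core with one ring nitrogen; compound 3 `Oc1ccc(C#CC#Cc2ccccc2)cc1` and compound 4 `Nc1ccc(C#CC#Cc2ccc(O)cc2)cc1` share a phenol core. How the two cores differ is not broken down here.

In a physicochemical assay for acid dissociation, compound 1 gives 3.3, and compound 2 gives 5. The change between them, (amino in place of hydrogen on an aromatic carbon), produced a step of a number 1.70 log units higher from compound 1 to compound 2 (beyond the scatter). Compound 3 gives 9.5 in this assay, the highest of the three measured numbers.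

The change from compound 3 to compound 4 is the same kind of change: amino in place of hydrogen on an aromatic carbon. Its surroundings differ, though. In compound 2 the amino group enters next to the ring nitrogen, meta to a large group, on a ring with one nitrogen; in compound 4 it enters on a ring of carbon only, para to a large group. Among the compounds with values here, the single measured step therefore gives only a rough guide. Because compound 3 already gives 9.5, and because compound 2 showed a number 1.70 log units higher from compound 1 to compound 2 (beyond the scatter) in a setting that was not the same, a smaller step is expected here, a number 0.20 log units higher from compound 3 to compound 4 (within the scatter). Compound 4 is estimated to give 9.7 in this assay, between 9.2 and 10.2.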

Compound 4, acid dissociation constant: 2.8
Beside the measured number, compound 4's estimate is 6.90 log units above it, and the stated range ends above it.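

In this assay the amino-for-hydrogen change gave a number 6.70 log units lower from compound 3 to compound 4 (beyond the scatter) on the phenol core, whereas the same change gave a number 1.70 log units higher from compound 1 to compound 2 (beyond the scatter) on the other core. The change therefore did not carry from one core to the other in this series: the two steps run in opposite directions, so the step on one core gave no safe reading of the step on the other. Within the data shown here, what the pair does not show is whether the core, the place of the amino group or the site to which each number belongs sets the two steps apart, since the amino group enters in different surroundings and there is only one step per core, and nothing measured here gives a reason for the reversal.

The compounds shown leave open whether a methylamino or an acetamido group in place of the amino group would follow the step seen on one core, the other or neither. As far as these compounds go, it also remains open how the number of compound 4 would respond to a methoxy group in place of its phenol hydroxyl, a single change that could be compared directly with compound 4.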